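Series notes: trimethoxyphenyl variant of the benzylpiperazine amide

This account rests on a few compounds, and the source may have more. Where it says the series, first, only, none or still open, it means among the compounds named here.

Measured compounds:
compound 1 `O=C(CN[C@H]1CCN(S(=O)(=O)Cc2ccccc2)C1)N1CCN(Cc2cccc(Cl)c2)CC1` — in a functional assay on K562 cells (Homo sapiens) for cytotoxicity, read by MTT assay, with a stated time of 48 h (a higher number here means a weaker inhibitor, a lower number a stronger inhibitor), compound 1 gives 8600 nM
compound 2 `O=C(CN[C@H]1CCN(S(=O)(=O)Cc2ccccc2)C1)N1CCN(Cc2cccc(C(F)(F)F)c2)CC1` — compound 2 gives 3600 nM
compound 3 `COc1cccc(CN2CCN(C(=O)CN[C@H]3CCN(S(=O)(=O)Cc4ccccc4)C3)CC2)c1` — compound 3 gives 60800 nM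

Compound 1 holds the second highest number of the three. Its nearest neighbour is compound 2, a 2.4-fold lower number from compound 1 to compound 2 (0.38 log units; beyond the scatter); its furthest is compound 3, a 7.1-fold higher number from compound 1 to compound 3 (0.85 log units; beyond the scatter). The step to compound 4 `COc1cc(CN2CCN(C(=O)CN[C@H]3CCN(S(=O)(=O)Cc4ccccc4)C3)CC2)cc(OC)c1OC` is 3,4,5-trimethoxyphenyl in place of 3-chlorophenyl on a saturated chain carbon bound to an amine nitrogen in a ring. Among the compounds with values here, the steps that bear on it are a 7.1-fold higher number from compound 1 to compound 3 (0.85 log units; beyond the scatter) and a 17-fold higher number from compound 2 to compound 3 (1.23 log units; beyond the scatter), both showing that methoxy on the aromatic carbon raises the number. Compound 4 carries three such methoxy groups, so a rise at least as large as that of compound 3 is expected, and likely larger. The number expected for compound 4 is 50000 nM, within 15000 nM to 150000 nM, a step of a 5.8-fold higher number from compound 1 to compound 4 (0.76 log units; beyond the scatter).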

Compound 4, half-maximal inhibitory concentration: 93000 nM
Compound 4: middle estimate off by 1.9-fold (0.27 log units), on the low side; measured number inside the range.
By their numbers in this assay, from the lowest: compound 2; then compound 1; then compounds 3 and 4 (each within the scatter of the next).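

In this assay, 3,4,5-trimethoxyphenyl on a saturated chain carbon bound to an amine nitrogen in a ring gives an 11-fold higher number from compound 1 to compound 4 (1.03 log units; beyond the scatter) and a 26-fold higher number from compound 2 to compound 4 (1.41 log units; beyond the scatter), so the higher numbers seen with 3-methoxyphenyl extend to this larger group. The remaining step is a 1.5-fold higher number from compound 3 to compound 4 (0.18 log units; within the scatter), so compounds 3 and 4 cannot be told apart in this assay, whatever the count of methoxy groups. No measured evidence accounts for these results.

Open, on these data alone, is how a phenyl group carrying an amine or a carboxylic acid at this place would compare with 3-(trifluoromethyl)phenyl.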